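Replacing the 1-isobutylpiperidin-4-yl group of compound 3

The source may hold more compounds than are shown below. What is called first, only, known or untested is meant among the compounds shown, and "the series" means these compounds.

In an ADME assay on a cell-free system (plasma, Mus musculus) for metabolic stability, read by LC-MS, tested at 2 uM (a lower number here means that the compound disappears faster, a higher number that the compound lasts longer), compound 1 `CC(=O)N1CCC(c2ccc3c(c2)oc(=O)n3C(=O)NCCCCc2ccccc2)CC1` gives 0.5 h, compound 2 `CN1CCN(c2ccc3c(c2)oc(=O)n3C(=O)NCCCCc2ccccc2)C(=O)C1` gives 0.333 h and compound 3 `CC(C)CN1CCC(c2ccc3c(c2)oc(=O)n3C(=O)NCCCCc2ccccc2)CC1` gives 1 h. Of the steps reaching compound 3, a 2.0-fold higher number from compound 1 to compound 3 (0.30 log units; within the scatter) stays within the scatter and only a 3.0-fold higher number from compound 2 to compound 3 (0.48 log units; beyond the scatter) goes beyond it. Compound 3 therefore stands clear of compound 2 only.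

Compound 4 `CN1CCN(c2ccc3c(c2)oc(=O)n3C(=O)NCCCCc2ccccc2)CC1` differs from compound 3 as follows: 4-methylpiperazin-1-yl in place of 1-isobutylpiperidin-4-yl on an aromatic carbon. Its 4-methylpiperazin-1-yl group comes closest to the 4-methyl-2-oxopiperazin-1-yl group of compound 2, so a 3.0-fold higher number from compound 2 to compound 3 (0.48 log units; beyond the scatter) is the best guide, run in reverse. The step of a 1.5-fold lower number from compound 1 to compound 2 (0.18 log units; within the scatter) adds little. Among the measured compounds shown here, no measured pair isolates the ring carbonyl. The expected step is a 2.0-fold lower number from compound 3 to compound 4 (0.30 log units; within the scatter). For compound 4 the estimated half-life is 0.5 h, expected between 0.25 h and 1 h.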

Compound 4, half-life: < 0.0834 h
Compound 4 ended at the assay's limit (the forecaster's own chance of this, stated with the estimate: 3%); middle value at least 5.9-fold (0.77 log units) away from the limit.
By their numbers in this assay, from the lowest: compounds 2, 1 and 3 (each within the scatter of the next, the first and the last beyond it). At a limit, below all of these: compound 4.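

Compound 4 stands at a limit of the assay, not at a number: the limit of < 0.0834 h in this assay, at which 1 of the 4 values shown sits. All three steps to it lie beyond the scatter: an at least 11-fold lower number from compound 3 to compound 4 (1.07 log units; beyond the scatter), an at least 3.9-fold lower number from compound 2 to compound 4 (0.60 log units; beyond the scatter) and an at least 5.9-fold lower number from compound 1 to compound 4 (0.77 log units; beyond the scatter). Among the compounds shown here, the step from compound 2 removes only the ring carbonyl, so a single change at this aromatic carbon can move the half-life further than the earlier compounds showed.

Going by these compounds, the true size of these steps stays open at a limit. A 1-methylpiperidin-4-yl or 4-isobutylpiperazin-1-yl group would separate the ring nitrogen from the group it carries.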